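A few compounds are considered here, and "the series" means these few. Any claim that something is new, unique, unknown or untested is made for them only; others in the source may bear on it.

Measured so far in an ADME assay on HepG2 cells (Homo sapiens) for cytotoxicity, read by luminescence, with a stated time of 72 h; on this read-out lower numbers stand for an effect already at smaller amounts and higher numbers for an effect only at larger amounts of compound:
- Compound 1 `CCOC(=O)c1c(-c2cccc(Oc3ccccc3)c2)[nH]c2cc(OC)c(F)cc2c1=O`: > 21500 nM, a limit
- Compound 2 `CCOC(=O)c1c(-c2cccc(-c3c(C)cccc3C)c2)[nH]c2cc(OC)c(F)cc2c1=O`: > 21500 nM, a limit

Compound 1 has only a limit and no exact number. The measurements so far all end at the limit of > 21500 nM in this assay, at which 2 of the 2 values shown sit.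

Compound 3 `COc1cc2[nH]c(-c3cccc(Oc4ccccc4)c3)c(C(=O)NCCN3CCCC3)c(=O)c2cc1F` differs from compound 1 in one place: (2-(pyrrolidin-1-yl)ethyl)amino in place of ethoxy on a carbonyl carbon. Ethoxycarbonyl thus becomes (2-(pyrrolidin-1-yl)ethyl)carbamoyl. Going by the values given here, the only measured step, a step that the two limits leave unreadable from compound 1 to compound 2, concerns a different group and offers no size to carry over. The expectation therefore rests on the structural change alone and stays loose: a group this different may bring a readable effect in this assay, so a moderate move toward lower numbers is expected, though another limit is quite possible. The expected change is an at least 1.6-fold lower number from compound 1 to compound 3 (0.21 log units; that floor lies within the scatter). For compound 3 the estimate is 13000 nM, with an expected range of 5000 nM to 21500 nM.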

Compound 3, half-maximal effective concentration: > 21500 nM
Compound 3 was reported as a limit; the forecaster's own chance of this, stated with the estimate: 50%; middle value at least 1.6-fold (0.21 log units) from the limit.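

In this assay compound 1 and compound 3 both give only a limit, so the change from ethoxy to (2-(pyrrolidin-1-yl)ethyl)amino has no readable size: the limit of > 21500 nM in this assay, at which 3 of the 3 values shown sit.

The compounds shown leave open at what concentration, if any, each would reach a half-maximal effect on these cells.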